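Methylating the hydroxy of compound 1

The source may hold more compounds than are shown below. What is called first, only, known or untested is meant among the compounds shown, and "the series" means these compounds.

Measured compounds:
compound 1, `CCCCCCCCCCCCCC1=C(O)C(=O)C=C(NCCCC(=O)OC(C)(C)C)C1=O`, 37%
compound 2, `CCCCCCCCCCCCCC1=C(O)C(=O)C=C(NCCCC(=O)O)C1=O`, 24%

The measurements come from a functional assay on GM15850 cells (Homo sapiens) for inhibition, read by flow cytometry, with a stated time of 16 h, tested at 10 uM; on this read-out lower numbers stand for a weaker effect and higher numbers for a stronger effect at the one concentration tested. In this assay compound 1 gives 37%, the higher of the two numbers recorded, and compound 2 gives 24%. Within the data shown here, the one step recorded between them, a number 13 percentage points lower from compound 1 to compound 2 (beyond the scatter), concerns the ester end of the chain, where hydrogen replaces tert-butyl on an oxygen next to a carbonyl group.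

Compound 3, `CCCCCCCCCCCCCC1=C(OC)C(=O)C=C(NCCCC(=O)OC(C)(C)C)C1=O`, has not yet been measured. It differs from compound 1 in another place: methyl in place of hydrogen on an oxygen on an unsaturated carbon. Among the measured compounds shown here, the recorded step from compound 1 to compound 2 does not touch this oxygen, so no measured step bears directly on the change from hydroxy to methoxy. The step from compound 1 to compound 3 is therefore expected to be a number 5 percentage points lower from compound 1 to compound 3 (within the scatter), with no direction that the data can support and a wide uncertainty. Compound 3 is expected to give an estimated 32%, between 10% and 55%.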

Compound 3, a percentage reported as activity, at one concentration (the size of the read-out at that concentration, not a potency): 86%
For compound 3 the middle estimate is 54 percentage points below the measured one; the whole stated range lies below it.
By their numbers in this assay, from the lowest: compound 2; then compound 1; then compound 3.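

At the oxygen on an unsaturated carbon, replacing hydrogen with methyl produces a number 49 percentage points higher from compound 1 to compound 3 (beyond the scatter) in this assay, so this hydroxy-to-methoxy change has a large effect on the read-out at the one concentration tested. Among these compounds, until now the only recorded change was at the ester end of the chain, a number 13 percentage points lower from compound 1 to compound 2 (beyond the scatter), a modest step that showed nothing about this oxygen; the new step shows that the oxygen is a far more sensitive place in this pair of compounds. The data shown offer no measured finding that would explain the result.

The compounds shown leave open whether an ethoxy group or a longer alkoxy chain on this oxygen, or an amine in place of the hydroxy, would keep, extend or lose the effect seen with methoxy. They also leave open whether methoxy would have a comparable effect with the carboxylic acid end of compound 2 , since the change is shown here only with the tert-butyl ester of compound 1 .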